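Swapping a dinitrophenyl for a benzyl: cytotoxicity expectations

The source may hold more compounds than are shown below. What is called first, only, known or untested is meant among the compounds shown, and "the series" means these compounds.

Of the compounds shown here, three sharing one core have been tested in an ADME assay on HEK-293T cells (Homo sapiens) for cytotoxicity, read by CCK-8 assay, with a stated time of 48 h; on this read-out higher numbers stand for weaker inhibition and lower numbers for stronger inhibition. Compound 1 `O=C(NCCNS(=O)(=O)c1ccc(-c2ccccc2Oc2ccc(O)c(O)c2)s1)Nc1cc(Cl)cc(Cl)c1` gives 12400 nM in this assay. Compound 2 `COc1ccc(NC(=O)NCCNS(=O)(=O)c2ccc(-c3ccccc3Oc3ccc([N+](=O)[O-])cc3)s2)cc1` reaches only a limit of this assay, > 20000 nM, and no number. Compound 3 `O=C(NCCNS(=O)(=O)c1ccc(-c2ccccc2Oc2ccc([N+](=O)[O-])c([N+](=O)[O-])c2)s1)Nc1cc(C(F)(F)F)cc(C(F)(F)F)c1` likewise stands at a limit of this assay, > 50000 nM, so its true value is known only as lying past that point. Among the three values shown, compound 3 therefore sits at the highest limit, with compound 2 at a lower one and compound 1 the only compound with a measured number.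

Compound 4 `O=C(NCCNS(=O)(=O)c1ccc(-c2ccccc2OCc2ccccc2)s1)Nc1cc(C(F)(F)F)cc(C(F)(F)F)c1` is the next candidate. It differs from compound 3 at one place: benzyl in place of 3,4-dinitrophenyl on an oxygen on an aromatic ring.

For the measured compounds named here, no step between two measured compounds is available here to anchor an expectation, so the size of the change from compound 3 to compound 4 in this assay is uncertain. The expected outcome is a step from compound 3 to compound 4 of about an at least 1.6-fold lower number from compound 3 to compound 4 (0.22 log units; that floor lies within the scatter), which might or might not fall beyond the scatter, and could lie in either direction. Compound 4 is estimated to give about 30000 nM in this assay, within a range from 8000 nM to 100000 nM.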

Compound 4, half-maximal inhibitory concentration: > 20000 nM
Compound 4: no number, only a limit; the forecaster's own chance of this, stated with the estimate: 50%; the middle value does not contradict the limit.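

Compound 3 and compound 4 both reach only limits in this assay, with no measured number, so the step between them cannot be read. The compounds shown leave open whether benzyl in place of 3,4-dinitrophenyl changes this read-out at all, and in which direction.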